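The compounds below may be only part of what the source reports. "The series", "measured", "known", "first", "only" and "open" are said of these compounds alone.

Compound 1 `O=C(CCCCCCc1ccccc1)c1ncc(-c2cccs2)s1`: in an assay for inhibition of Fatty-acid amide hydrolase 1 (Rattus norvegicus), at pH 9.0 (a higher number here means a weaker inhibitor, a lower number a stronger inhibitor), compound 1 gives 2000 nM.
Compound 2 `O=C(CCCCCCc1ccccc1)c1ccc(-c2ccco2)nn1`: in this assay compound 2 gives 40 nM.
Compound 3 `O=C(CCCCCCc1ccccc1)c1nnn(-c2ccco2)n1`: in this assay compound 3 gives 5 nM.

Compound 3 has the lowest number of the three; compound 2 stands nearest, and the gaps to compound 2 and to compound 1 both lie beyond the scatter, so compound 3 is the strongest inhibitor among them. Compound 4 `O=C(CCCCCCc1ccccc1)c1nnn(-c2cccs2)n1` differs from compound 3 in one place: thiophen-2-yl in place of furan-2-yl on an aromatic nitrogen. Among the measured compounds shown here, no pair of measured compounds isolates this change; compound 1 and compound 2 carry the two groups on different cores, so their values cannot show it on their own. In this assay a step of no size beyond the scatter is expected, with perhaps a slight drift towards a higher number. Compound 4 is expected to give 7 nM, within 2 nM to 25 nM. This corresponds to an expected step of a 1.4-fold higher number from compound 3 to compound 4 (0.15 log units; within the scatter).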

Compound 4, inhibition constant: 8.5 nM
The estimate for compound 4 lay 1.2-fold (0.08 log units) below the measured number, within the range that was stated.
By their numbers in this assay, from the lowest: compounds 3 and 4 (each within the scatter of the next); then compound 2; then compound 1.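

In this assay, thiophen-2-yl in place of furan-2-yl on an aromatic nitrogen gives a 1.7-fold higher number from compound 3 to compound 4 (0.23 log units; within the scatter), a step that stays within the scatter. Unlike compound 1 and compound 2, which carry these groups on different cores, this pair compares them on one shared core, and at this position their numbers cannot be told apart. Going by these compounds, whether a phenyl ring or a saturated cyclohexyl ring on that nitrogen would keep a number of this size remains open. Nothing measured here bears on why the two groups give such similar numbers.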